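This account rests on a few compounds, and the source may have more. Where it says the series, first, only, none or still open, it means among the compounds named here.

Of the compounds shown here, two built on one shared core have been tested in a functional assay on HepG2 cells (Homo sapiens) for cytotoxicity, read by MTT assay, with a stated time of 48 h; a higher number here means a weaker inhibitor, a lower number a stronger inhibitor. Compound 1, `COc1cc(-c2nnc3n2NC(c2ccco2)C(C(=O)C2CC2)S3)cc(OC)c1OC`, carries a cyclopropyl on its carbonyl carbon; in this assay compound 1 reaches only a limit, > 100000 nM, rather than a number. Compound 2, `COc1cc(-c2nnc3n2NC(c2ccco2)C(C(=O)c2cccc(Br)c2)S3)cc(OC)c1OC`, has the same core with a 3-bromophenyl in place of that cyclopropyl; in this assay compound 2 likewise stops at a limit, > 100000 nM. The step between them is a step that the two limits leave unreadable from compound 1 to compound 2, so its size cannot be read. On the numbers shown, compound 2 therefore stands at the limit, exactly as compound 1 does (the limit of > 100000 nM in this assay, at which 2 of the 2 values shown sit).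

Compound 3, `COc1cc(-c2nnc3n2NC(c2ccco2)C(C(=O)c2ccco2)S3)cc(OC)c1OC`, differs from compound 2 in one place: furan-2-yl in place of 3-bromophenyl on a carbonyl carbon. Among the compounds with values here, no measured step tells what an exchange of this kind on the carbonyl carbon does, since the single step available is unreadable. The expected step is a number no higher from compound 2 to compound 3 (the limit leaves the size open), meaning no shift beyond the scatter that can be foreseen from the data. Compound 3 is therefore expected to come out near 100000 nM, within a range from 40000 nM to 300000 nM, and most probably it will again be reported only as a limit.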

Compound 3, half-maximal inhibitory concentration: > 100000 nM
Compound 3 gave a limit, no number (the forecaster's own chance of this, stated with the estimate: 85%); the middle value lies on the limit itself.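

Compound 3 also stops at a limit in this assay, so the steps among compound 1, compound 2 and compound 3 cannot be read: the limit of > 100000 nM in this assay, at which 3 of the 3 values shown sit.

The compounds shown leave open whether any group on the carbonyl carbon of the shared core can bring the result down to a readable number, and how large such a step would be.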